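Working notes: the formyl step from compound 2

The source may report more compounds than this note shows. Statements on the series, on what has been measured and on what is new or still open speak of the compounds shown alone.

In a functional assay on MV4-11 cells (Homo sapiens) for inhibition, read by resazurin assay, with a stated time of 72 h (on this read-out lower numbers stand for stronger inhibition of growth and higher numbers for weaker inhibition of growth), compound 1 `Cc1ccc(-c2cncc(Cl)c2N2CCC3(CCNC3=O)CC2)o1` gives 4950 nM, and compound 2 `Cc1ccc(-c2cncc(Cl)c2N2CCC3(CCNC3=O)CC2)s1` gives 650 nM. Compound 2 therefore holds the lower of the two numbers, the stronger growth inhibition in this small set. Among the compounds with values here, the only measured step, a 7.6-fold lower number from compound 1 to compound 2 (0.88 log units; beyond the scatter), places 5-methylthiophen-2-yl where 5-methylfuran-2-yl stood and is modest in size.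

Next comes compound 3 `Cc1cc(-c2cncc(Cl)c2N2CCC3(CCNC3=O)CC2)sc1C=O`, in which 5-formyl-4-methylthiophen-2-yl replaces 5-methylthiophen-2-yl on the same aromatic carbon: 5-formyl-4-methylthiophen-2-yl in place of 5-methylthiophen-2-yl on an aromatic carbon. This carbon is ortho to a large group, two atoms from the ring nitrogen and meta to a chloro group.

The measured step shows that a change at this place can move the number beyond the scatter. Within the data shown here, no measured compound carries a formyl group, so the direction is poorly fixed. Among the measured compounds shown here, a modest shift towards a higher number is expected, no larger than a step of that size. The estimated change is a 1.5-fold higher number from compound 2 to compound 3 (0.19 log units; within the scatter). In this assay the estimate for compound 3 is 1000 nM, with an expected range of 250 nM to 4000 nM.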

Compound 3, concentration for 50% growth inhibition: 2530 nM
The estimate for compound 3 lay 2.5-fold (0.40 log units) below the measured number, and the stated range covers the measured number.
By their numbers in this assay, from the lowest: compound 2; then compounds 3 and 1 (each within the scatter of the next).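

Compound 3 keeps the thiophene of compound 2, yet the change in substituents on that ring alone moves the result in this assay: a 3.9-fold higher number from compound 2 to compound 3 (0.59 log units; beyond the scatter). Within the data shown here, the ring swap in the earlier step is therefore not the only change at this aromatic carbon that can shift the number beyond the scatter, and a thiophene at this place does not by itself secure the lower number of compound 2. Compound 3 goes against any reading of thiophene as better than furan here, with a 2.0-fold lower number from compound 1 to compound 3 (0.29 log units; within the scatter), so its 5-formyl-4-methylthiophen-2-yl cannot be told apart from the 5-methylfuran-2-yl of compound 1, and no measurement shown bears on why the number rose from compound 2.

The formyl group and the altered methyl placement enter together, so the compounds shown do not assign the step to either one, and a 5-formylthiophen-2-yl would be needed to separate them. Also open, going by these compounds, is how a carboxylic acid, a nitrile or an aminomethyl group would behave in place of the formyl group on the thiophene.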